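Difluoromethoxy for chloro on compound 3: expected activation

The source may report more compounds than this note shows. Statements on the series, on what has been measured and on what is new or still open speak of the compounds shown alone.

Compound 3 `Oc1nc2nonc2nc1Nc1ccc(Cl)cc1` gives 11700 nM in an assay on mitochondria from L6 cells (Rattus norvegicus) for activation, with a stated time of 90 min (on this read-out higher numbers stand for an effect only at larger amounts of compound and lower numbers for an effect already at smaller amounts), the highest of the three numbers; compound 1 `CCc1ccc(Nc2nc3nonc3nc2O)cc1` gives 10700 nM and sits within the scatter of compound 3, while compound 2 `CCCCCc1ccc(Nc2nc3nonc3nc2O)cc1` gives 2400 nM. Compound 4 `Oc1nc2nonc2nc1Nc1ccc(OC(F)F)cc1` differs from compound 3 by difluoromethoxy in place of chloro on an aromatic carbon. Going by the values given here, two measured steps bear on this position: a 1.1-fold higher number from compound 1 to compound 3 (0.04 log units; within the scatter) and a 4.9-fold higher number from compound 2 to compound 3 (0.69 log units; beyond the scatter), so only the pentyl chain moved the number beyond the scatter, and an exchange of small groups did not. The difluoromethoxy group lies between chloro and pentyl in what it adds. The step toward a lower number is therefore expected to be a 1.7-fold lower number from compound 3 to compound 4 (0.22 log units; within the scatter). Compound 4 is therefore estimated at 7000 nM, with a range of 2500 nM to 20000 nM.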

Compound 4, half-maximal effective concentration: 20600 nM
The estimate for compound 4 lay 2.9-fold (0.47 log units) below the measured number; measured number outside the range, above it.
By their numbers in this assay, from the lowest: compound 2; then compounds 1, 3 and 4 (each within the scatter of the next).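

Difluoromethoxy on this aromatic carbon gives no separation from the small groups: the change from chloro is a 1.8-fold higher number from compound 3 to compound 4 (0.25 log units; within the scatter) and the change from ethyl is a 1.9-fold higher number from compound 1 to compound 4 (0.28 log units; within the scatter), so compound 1, compound 3 and compound 4 cannot be told apart. Only the pentyl chain stands apart, with an 8.6-fold higher number from compound 2 to compound 4 (0.93 log units; beyond the scatter), so the added heavy atoms of difluoromethoxy did not bring the lower number seen with pentyl. No measurement at hand accounts for this difference.

As far as these compounds go, whether a longer chain such as octyl would lower the number further remains open. So does how an amine or a carboxylic acid would behave at this position.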